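Amide aryl change and kinetic solubility: compound 2 to compound 3

The compounds below may be only part of what the source reports. "The series", "measured", "known", "first", "only" and "open" are said of these compounds alone.

Measured compounds:
compound 1 `COc1ccc2nc(C)cc(OCC(=O)Nc3cccc(C)c3)c2c1`: 193000 nM
compound 2 `COc1ccc2nc(C)cc(OCC(=O)Nc3ccc(Cl)cc3Cl)c2c1`: 20500 nM

In a physicochemical assay for solubility, in phosphate buffer, measured as kinetic solubility, with a stated time of 1 h, at pH 7.4 (a higher number here means a more soluble compound, a lower number a less soluble compound), compound 1 gives 193000 nM and compound 2 gives 20500 nM. Within the data shown here, compound 2 stands lowest of the two numbers measured so far; its only neighbour is compound 1, reached by the single measured step, a 9.4-fold lower number from compound 1 to compound 2 (0.97 log units; beyond the scatter).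

Compound 3 `COc1ccc2nc(C)cc(OCC(=O)Nc3ccc(Cl)cc3)c2c1` has not yet been measured in this assay. It differs from compound 2 by hydrogen in place of chloro on an aromatic carbon. Among the measured compounds shown here, only the step from compound 1 to compound 2 bears on this change, and it bears on it only in part: that step exchanged the whole amide aryl group and moved the number down beyond the scatter. Removing one chloro from compound 2 reverses part of that exchange, so the number for compound 3 is expected to rise from compound 2, though by less than the whole span, because a 9.4-fold lower number from compound 1 to compound 2 (0.97 log units; beyond the scatter) covers both chloro groups and the methyl together.

The expected step for compound 3 is a 2.4-fold higher number from compound 2 to compound 3 (0.39 log units; beyond the scatter). The estimate for compound 3 is 50000 nM, with a range from 20000 nM to 130000 nM.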

Compound 3, solubility: 9000 nM
For compound 3 the middle estimate is 5.6-fold (0.74 log units) above the measured one, and the stated range ends above it.
By their numbers in this assay, from the lowest: compound 3; then compound 2; then compound 1.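

In this assay, the chloro group on the aromatic carbon ortho to a large group and meta to a chloro group proves separable from the rest of the 2,4-dichlorophenyl group, and replacing it with hydrogen gives a 2.3-fold lower number from compound 2 to compound 3 (0.36 log units; beyond the scatter), so the loss of this one heavy atom goes with a drop rather than a rise. The earlier pair could not show this, since the step of a 9.4-fold lower number from compound 1 to compound 2 (0.97 log units; beyond the scatter) exchanged the whole aryl group at once. The exchange of 3-methylphenyl for 4-chlorophenyl gives a 21-fold lower number from compound 1 to compound 3 (1.33 log units; beyond the scatter), a larger step than the one to the 2,4-dichlorophenyl compound, which places compound 3 lowest of the three and shows that, in these compounds, adding the second chloro group does not extend the drop.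

The step from compound 1 to compound 3 still changes both the group and its place on the ring, so the share of the methyl group and that of the chloro group stay apart from each other only in part. Also open, on these data alone, is how the number would move with an amine or a carboxylic acid on this aryl ring. Nothing measured here speaks to the cause of these shifts.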